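Removing One Methoxy Group from Compound 2

The compounds below may be only part of what the source reports. "The series", "measured", "known", "first", "only" and "open" are said of these compounds alone.

Compound 2 `COc1ccc(C(=O)/C=C/c2cc(-c3cc(OC)c(OC)c(OC)c3)n[nH]2)cc1OC` gives -15% in a functional assay on CCRF-CEM cells (Homo sapiens) for cytotoxicity, read by sulforhodamine B assay, with a stated time of 48 h, tested at 100 uM (on this read-out higher numbers stand for a weaker effect at the one concentration tested and lower numbers for a stronger effect), the highest of the two numbers measured, with compound 1 `COc1cc(-c2cc(/C=C/C(=O)c3ccc(N)cc3)[nH]n2)cc(OC)c1OC` nearest at -21%, a gap within the usual scatter. Compound 3 `COc1ccc(C(=O)/C=C/c2cc(-c3cc(OC)c(OC)c(OC)c3)n[nH]2)cc1` differs from compound 2 in one place: hydrogen in place of methoxy on an aromatic carbon. For the measured compounds named here, the only measured step touching this part of the molecule is a number 6 percentage points higher from compound 1 to compound 2 (within the scatter), which exchanged the whole group on the carbonyl carbon and stayed within the scatter. Going by the values given here, no step of the present kind has been measured, so the expected step is a number 3 percentage points higher from compound 2 to compound 3 (within the scatter), nothing beyond the scatter. Compound 3 is therefore expected to give -12%, between -35% and 10%.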

Compound 3, a percentage reported as activity, at one concentration (the size of the read-out at that concentration, not a potency): -16%
Beside the measured number, compound 3's estimate is 4 percentage points above it; the measured number falls inside the stated range.
By their numbers in this assay, from the lowest: compounds 1, 3 and 2 (each within the scatter of the next).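

In this assay, hydrogen in place of methoxy gives a number 1 percentage points lower from compound 2 to compound 3 (within the scatter), so at this position the 3,4-dimethoxyphenyl and 4-methoxyphenyl compounds cannot be told apart. Methoxy in place of amino gives a number 5 percentage points higher from compound 1 to compound 3 (within the scatter), so that exchange on an aromatic carbon cannot be told apart from the scatter either. Nothing measured bears on the reason for these results. Still open, on these data alone, is whether an amine or a carboxylic acid on the carbon that lost its methoxy would shift the number. One concentration also shows only the size of the effect at that concentration.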